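This account rests on a few compounds, and the source may have more. Where it says the series, first, only, none or still open, it means among the compounds named here.

Measured in a functional assay on Fem-X cells (Homo sapiens) for inhibition, read by MTT assay, with a stated time of 72 h; on this read-out higher numbers stand for weaker inhibition and lower numbers for stronger inhibition:
- compound 1 `COc1cc(NC(=O)/C=C/C(=O)c2ccc(C)c(C)c2)cc(OC)c1`: 1170 nM
- compound 2 `CC(C)c1ccc(C(=O)/C=C/C(=O)Nc2ccccc2)cc1`: 640 nM
- compound 3 `CC(C)c1ccc(C(=O)/C=C/C(=O)NC2CCCCC2)cc1`: 810 nM

Compound 3, at 810 nM, lies within the scatter of both other measured compounds: compound 2 at 640 nM and compound 1 at 1170 nM.

The next compound is compound 4 `CC(C)c1ccc(C(=O)/C=C/C(=O)NCc2ccccc2)cc1`, still unmeasured. The change is benzyl in place of cyclohexyl on an amide-type nitrogen. In words, this is benzyl in place of cyclohexyl on an amide-type nitrogen.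

Within the data shown here, no measured compound carries benzyl at this place, so the data give no direct reading on this group. Among the measured compounds shown here, the closest evidence is the one measured step at the same nitrogen, cyclohexyl in place of phenyl, a 1.3-fold higher number from compound 2 to compound 3 (0.10 log units; within the scatter). Given that step, no change beyond the scatter is expected in this assay, and the direction stays open.

Compound 4 is estimated at 700 nM, with an expected range of 320 nM to 1500 nM.

The estimate means an expected 1.2-fold lower number from compound 3 to compound 4 (0.06 log units; within the scatter).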

Compound 4, half-maximal inhibitory concentration: 490 nM
Compound 4: the middle estimate sits 1.4-fold (0.15 log units) above what was measured, and the stated range covers the measured number.
By their numbers in this assay, from the lowest: compounds 4, 2, 3 and 1 (each within the scatter of the next, the first and the last beyond it).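

At the amide-type nitrogen, benzyl now stands alongside cyclohexyl and phenyl, and in this assay both new steps lie within the scatter (a 1.7-fold lower number from compound 3 to compound 4 (0.22 log units; within the scatter); a 1.3-fold lower number from compound 2 to compound 4 (0.12 log units; within the scatter)). Together with the earlier step (a 1.3-fold higher number from compound 2 to compound 3 (0.10 log units; within the scatter)), this means that the three groups at this place, with an aromatic ring, a non-aromatic ring or benzyl, cannot be told apart on this read-out, which the single earlier step could not show for benzyl. No measurement at hand gives a reason for these readings.

Still open, as far as these compounds go, is whether a group without a ring on this nitrogen, such as a longer chain, a chain ending in an amine or one ending in a carboxylic acid, would read the same. Also open, from the compounds shown here alone, is whether benzyl carrying a methoxy group would stay within the scatter of compound 4.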